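The compounds below may be only part of what the source reports. "The series", "measured", "known", "first", "only" and "open" are said of these compounds alone.

Compound 1 `Cc1c(Cc2ccccc2)c(=O)oc2cc(OCC(O)CNCc3ccccc3)ccc12`: > 100000 nM
Compound 2 `Cc1c(Cc2ccccc2)c(=O)oc2cc(OCC(O)CNn3ccnn3)ccc12`: > 100000 nM

In an ADME assay on A549 cells (Homo sapiens) for cytotoxicity, read by CellTiter-Glo (on this read-out higher numbers stand for lower toxicity in this test and lower numbers for higher toxicity in this test), compound 1 gives > 100000 nM, which is a limit of the assay and not a number. Compound 2 likewise gives > 100000 nM, again a limit. Going by the values given here, the only measured step, a step that the two limits leave unreadable from compound 1 to compound 2, is therefore of unknown size, and compound 2 stands where (the limit of > 100000 nM in this assay, at which 2 of the 2 values shown sit). Compound 3 `Cc1c(Cc2ccccc2)c(=O)oc2cc(OCC(O)CNc3nc4ccccc4[nH]3)ccc12` differs from compound 2 in one place: 1H-benzimidazol-2-yl in place of 1H-1,2,3-triazol-1-yl on an amine nitrogen. Among the compounds with values here, no measured step reads on this change. Compound 3 is expected to sit at 100000 nM, between 40000 nM and 250000 nM. The expected step from compound 2 is a number no higher from compound 2 to compound 3 (the limit leaves the size open).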

Compound 3, half-maximal cytotoxic concentration: > 100000 nM
Compound 3 ended at the assay's limit; the forecaster's own chance of this, stated with the estimate: 70%; the middle value sits exactly at the limit.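

Going by these compounds alone, compound 3 joins compound 1 and compound 2 at a limit rather than a number, so no step among them can be read: the limit of > 100000 nM in this assay, at which 3 of the 3 values shown sit.

Left open is how far this assay would separate benzyl, 1H-1,2,3-triazol-1-yl and 1H-benzimidazol-2-yl on the amine nitrogen.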